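Amide nitrogen substituent change in a cytotoxicity series

A few compounds are considered here, and "the series" means these few. Any claim that something is new, unique, unknown or untested is made for them only; others in the source may bear on it.

Compound 1 `C=CC1=C(C(=O)O)C(c2ccc(OC)cc2)OC1` gives 44300 nM in a functional assay on HeLa cells (Homo sapiens) for cytotoxicity, read by MTT assay, with a stated time of 24 h; on this read-out lower numbers stand for stronger inhibition and higher numbers for weaker inhibition.
Compound 2 `C=CC1=C(C(=O)NC(C)(C)C)C(c2ccc(OC)cc2)OC1` is reported in this assay only as a limit, > 100000 nM.

Among the compounds with values here, compound 2 thus stands at the weak end of what has been measured: the single measured step, an at least 2.2-fold higher number from compound 1 to compound 2 (0.35 log units; beyond the scatter), carried it onto the assay limit (the limit of > 100000 nM in this assay, at which 1 of the 2 values shown sits). Compound 3 `C=CC1=C(C(=O)NCc2ccc(Cl)cc2)C(c2ccc(OC)cc2)OC1` differs from compound 2 by 4-chlorobenzyl in place of tert-butyl on an amide-type nitrogen. Within the data shown here, no measured step changes the substituent on the amide nitrogen, so nothing measured bears directly on this change; the acid-to-amide step is the only guide and points to weak values for amides. Compound 3 is therefore expected to stay near the limit, an expected step of a number no higher from compound 2 to compound 3 (the limit leaves the size open). The estimate for compound 3 is 100000 nM, expected between 30000 nM and 300000 nM.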

Compound 3, half-maximal inhibitory concentration: > 100000 nM
Compound 3: a limit, no number; the forecaster's own chance of this, stated with the estimate: 55%; the middle value sits exactly at the limit.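

Compound 2 and compound 3 are both reported only as limits, so no step between them can be read: the limit of > 100000 nM in this assay, at which 2 of the 3 values shown sit.

The compounds shown leave open whether any substituent on the amide nitrogen can bring a measurable value.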